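The source may hold more compounds than are shown below. What is called first, only, known or untested is meant among the compounds shown, and "the series" means these compounds.

Compound 1 `Cc1cc(C)cc(Cc2ccc3c(NCCCNCc4ccco4)ccnc3c2)c1` and compound 2 `c1ccc(CCc2ccc3c(NCCCNCc4ccco4)ccnc3c2)cc1` share one core and differ at a single saturated chain carbon bound to an aromatic carbon. In a physicochemical assay for solubility, with a stated time of 18 h, at pH 7.4 (on this read-out lower numbers stand for lower solubility and higher numbers for higher solubility), compound 1 gives 4200 nM, and compound 2 gives 4200 nM. The step of no change at the digits printed from compound 1 to compound 2 (within the scatter) shows that this exchange left the read-out within the scatter, so compound 2 stands level with compound 1 on the numbers shown. Compound 3 `CN(C)c1cccc(Oc2ccc3c(NCCCNCc4ccco4)ccnc3c2)c1` has not yet been measured. It differs from compound 2 in one place: 3-(dimethylamino)phenoxy in place of phenethyl on an aromatic carbon. Going by the values given here, the only measured step, no change at the digits printed from compound 1 to compound 2 (within the scatter), concerns a different kind of exchange on a chain carbon and bears on this one only loosely; no measured pair covers a phenoxy group or a dimethylamino group. The expectation is a step no larger than the scatter, and the estimated step is a 1.4-fold higher number from compound 2 to compound 3 (0.15 log units; within the scatter). Compound 3 is therefore expected to give 6000 nM, within a range from 2000 nM to 18000 nM.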

Compound 3, solubility: 14500 nM
For compound 3 the middle estimate is 2.4-fold (0.38 log units) below the measured one; the range from low to high includes it.
By their numbers in this assay, from the lowest: compounds 1 and 2 (each within the scatter of the next); then compound 3.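

On this aromatic carbon of the shared core, the exchange of phenethyl for 3-(dimethylamino)phenoxy gives a 3.5-fold higher number from compound 2 to compound 3 (0.54 log units; beyond the scatter) in this assay, and the exchange of 3,5-dimethylbenzyl for the same group gives a 3.5-fold higher number from compound 1 to compound 3 (0.54 log units; beyond the scatter) in the same read-out. The earlier exchange had left the read-out within the scatter, so these steps show that the number can move with the group at this position, here with a group that brings a nitrogen, an oxygen and hydrogen-bond acceptors that the leaving groups lack. Nothing available explains the rise.

Going by these compounds, the phenoxy oxygen and the dimethylamino group enter together, so their separate shares in the step remain open. An unsubstituted phenoxy, a 3-(dimethylamino)benzyl group or a carboxylic acid at this position would bear on that question.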